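A few compounds are considered here, and "the series" means these few. Any claim that something is new, unique, unknown or untested is made for them only; others in the source may bear on it.

Measured so far in a functional assay on HeLa cells (Homo sapiens) for antiproliferative activity, read by sulforhodamine B assay, with a stated time of 48 h; on this read-out lower numbers stand for stronger inhibition and higher numbers for weaker inhibition:
- compound 1 `COc1ccc(C(=O)/C=C\Nc2ccc(-c3nc4cc(OC)c(OC)c(OC)c4s3)cc2C)cc1O` gives 11400 nM
- compound 2 `COc1cc(OC)c2sc(-c3ccc(N/C=C\C(=O)c4ccc(OC)c(O)c4)cc3)nc2c1` gives 12100 nM
- compound 3 `COc1ccc(C(=O)/C=C\Nc2ccc(-c3nc4cc(OC)c(OC)c(OC)c4s3)cc2C)cc1[N+](=O)[O-]` gives 13400 nM

Compound 1 and compound 2 share the enaminone chain and the phenyl-benzothiazole part, but their cores are built differently; the difference between the two cores is not broken down here. Their values in this assay lie within the scatter of each other, so nothing can be read into their order.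

Compound 3 carries, on the core of compound 1, the change (nitro in place of hydroxy on an aromatic carbon). The step it made was a 1.2-fold higher number from compound 1 to compound 3 (0.07 log units; within the scatter), so the exchange left the activity essentially where it was.

Compound 4 `COc1cc(OC)c2sc(-c3ccc(N/C=C\C(=O)c4ccc(OC)c([N+](=O)[O-])c4)cc3)nc2c1` has not yet been measured. It differs from compound 2 by nitro in place of hydroxy on an aromatic carbon, the same change as that from compound 1 to compound 3, at the same place. Since compound 2 stands within the scatter of compound 1, and because a 1.2-fold higher number from compound 1 to compound 3 (0.07 log units; within the scatter) was itself within the scatter, a step of about a 1.2-fold higher number from compound 2 to compound 4 (0.06 log units; within the scatter) is expected. Compound 4 is therefore estimated at 14000 nM, with a range from 7000 nM to 28000 nM.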

Compound 4, half-maximal inhibitory concentration: 12900 nM
Beside the measured number, compound 4's estimate is 1.1-fold (0.04 log units) above it; the range from low to high includes it.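

In this assay, nitro in place of hydroxy on the core of compound 2 gave a 1.1-fold higher number from compound 2 to compound 4 (0.03 log units; within the scatter) and, set beside the earlier step, the change carries from one core to the other with no visible difference: the same change on two cores in this assay, a 1.2-fold higher number (0.07 log units; within the scatter) from compound 1 to compound 3 and a 1.1-fold higher number (0.03 log units; within the scatter) from compound 2 to compound 4, 1.1-fold (0.04 log units) apart, within the scatter of two such steps. On these two cores, then, the 3-hydroxy-4-methoxyphenyl and 4-methoxy-3-nitrophenyl forms cannot be told apart on this read-out. This does not show that the exchange would behave the same way on any further core, and with both steps within the scatter, a small dependence on the core could not be seen here.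

The compounds shown leave open what other groups at this place would give, such as an amine, a carboxylic acid or a fluorine atom in place of the hydroxy or nitro group. They also leave open what a longer chain in place of the enaminone chain would do on either core.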